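The source may report more compounds than this note shows. Statements on the series, on what has been measured and on what is new or still open speak of the compounds shown alone.

Compound 3 `COc1ccccc1/C=C1\CCC/C(=C\c2ccc(OC)c(OC)c2)C1=O` shares its core with compound 1 `COc1ccccc1/C=C1\CCC/C(=C\c2cccc(OC)c2OC)C1=O` and compound 2 `COc1cccc(/C=C2\CCC/C(=C\c3ccc(Cl)cc3Cl)C2=O)c1OC`. In an ADME assay on NHDF cells (Homo sapiens) for cytotoxicity, read by MTT assay, with a stated time of 72 h (a lower number here means a stronger inhibitor, a higher number a weaker inhibitor), compound 3 gives 18100 nM, the lowest of the three numbers shown; compound 1 gives 31300 nM, within the scatter of that, while compound 2 gives 49200 nM, beyond it. Compound 4 `COc1ccc(/C=C2\CCC/C(=C\c3ccc(O)c(O)c3)C2=O)cc1OC` differs from compound 3 by one change: 3,4-dihydroxyphenyl in place of 2-methoxyphenyl on a double-bonded chain carbon bound to a double-bonded ring carbon. Within the data shown here, the only measured step at this place, a 1.6-fold higher number from compound 1 to compound 2 (0.20 log units; within the scatter), swapped the same 2-methoxyphenyl for a different ring and stayed within the scatter. Among the measured compounds shown here, no measured step introduces a 3,4-dihydroxyphenyl, so the expectation rests on that single swap alone and is for no change beyond the scatter, a 1.1-fold higher number from compound 3 to compound 4 (0.04 log units; within the scatter). Compound 4 is therefore estimated at 20000 nM, with a range from 8000 nM to 50000 nM.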

Compound 4, half-maximal inhibitory concentration: 25200 nM
Estimate against measurement, compound 4: 1.3-fold (0.10 log units) below; the measured number falls inside the stated range.
By their numbers in this assay, from the lowest: compounds 3, 4, 1 and 2 (each within the scatter of the next, the first and the last beyond it).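

In this assay, putting 3,4-dihydroxyphenyl in place of 2-methoxyphenyl gives a 1.4-fold higher number from compound 3 to compound 4 (0.14 log units; within the scatter), even though the entering ring carries hydrogen-bond donors and the leaving one has none. Together with a 1.6-fold higher number from compound 1 to compound 2 (0.20 log units; within the scatter), this makes two different rings that have replaced 2-methoxyphenyl at this place without a change beyond the scatter. Nothing measured here explains why this swap changes so little. On these data alone, whether a ring bearing an amine or a carboxylic acid, or a longer chain in place of the ring, would shift the number beyond the scatter remains open.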